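The source may hold more compounds than are shown below. What is called first, only, known or untested is meant among the compounds shown, and "the series" means these compounds.

Compound 1 `COc1ccc(-c2cccc(S(=O)(=O)N3CCC(N4CCC(C)CC4)CC3)c2)cc1` was tested in a functional assay on DLD-1 cells (Homo sapiens) for antiproliferative activity, read by CellTiter-Glo, with a stated time of 72 h (a higher number here means a weaker inhibitor, a lower number a stronger inhibitor), and compound 1 gives 23 nM. Two further compounds built on the same core were tested alongside it. Compound 2 `CC1CCN(C2CCN(S(=O)(=O)c3ccc(Cl)nc3)CC2)CC1` gives 3700 nM in this assay, and compound 3 `Cc1cc(C)c(S(=O)(=O)N2CCC(N3CCC(O)CC3)CC2)c(C)c1` gives 106 nM. Of these three numbers, compound 1 has the lowest, making it the strongest inhibitor of the group; its gap to compound 3 and its larger gap to compound 2 both lie beyond the usual scatter of such measurements.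

Compound 4 `CC1CCN(C2CCN(S(=O)(=O)c3cccc(-c4ccccc4C(F)(F)F)c3)CC2)CC1` has not yet been measured. It differs from compound 1 in a single place: 2-(trifluoromethyl)phenyl in place of 4-methoxyphenyl on an aromatic carbon, sitting meta to a large group. For the measured compounds named here, no measured pair shows this particular exchange, so its effect cannot be read off from existing data. The expectation is a step from compound 1 to compound 4 of a 2.6-fold higher number from compound 1 to compound 4 (0.42 log units; beyond the scatter), toward a somewhat higher number, although it could also stay within the scatter. Compound 4 is therefore estimated at 60 nM, with a likely range from 15 nM to 250 nM.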

Compound 4, half-maximal inhibitory concentration: 10 nM
Beside the measured number, compound 4's estimate is 6.0-fold (0.78 log units) above it; the whole stated range lies above it.
By their numbers in this assay, from the lowest: compound 4; then compound 1; then compound 3; then compound 2.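

Within this set, this is the first pair that isolates the aromatic group sitting meta to a large group. In this assay, 2-(trifluoromethyl)phenyl in place of 4-methoxyphenyl gives a 2.3-fold lower number from compound 1 to compound 4 (0.36 log units; beyond the scatter), a modest step that nevertheless shows this position can change without a loss of activity. The entering group has more heavy atoms than the one that leaves and no hydrogen-bond acceptor, so for this pair neither the methoxy oxygen nor the smaller group is required for a low number.

As far as these compounds go, the effect of 4-(trifluoromethyl)phenyl or 2-methoxyphenyl at this carbon remains open, so the contributions of the new substituent and its new location on the phenyl ring cannot be separated. The compounds shown also offer no measurement that explains the step.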